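The source may hold more compounds than are shown below. What is called first, only, known or untested is meant among the compounds shown, and "the series" means these compounds.

Measured so far:
Compound 1 `COc1ccc(NC(=O)CCCCCCNC(=O)C(O)(O)C(F)(F)F)cc1`: "not determined" (no result reported)
Compound 2 `O=C(CCCCCCNC(=O)C(O)(O)C(F)(F)F)Nc1ccc(-c2ccccc2)cc1`: 3090 nM

In a functional assay on cells (Panel NCI-60 (60 carcinoma cell lines), Homo sapiens) for inhibition, read by colorimetric assay, with a stated time of 3 days (on this read-out higher numbers stand for weaker inhibition of growth and lower numbers for stronger inhibition of growth), compound 2 gives 3090 nM. Going by the values given here, this is the only number available, so it cannot yet be ranked as high or low within this small set. Among the compounds with values here, for compound 1 the entry reads "not determined" (no result reported), which leaves no measured pair to compare.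

The next compound is compound 3 `O=C(CCCCCCNC(=O)C(O)(O)C(F)(F)F)Nc1ccc(Cl)cc1`. It keeps the shared core and the chain of compound 2, but has chloro in place of phenyl on an aromatic carbon.

Within the data shown here, no measured step shows what such a swap does here, so the expectation is cautious: a small shift towards weaker inhibition of growth, possibly no larger than the usual scatter. The expected change is a 1.6-fold higher number from compound 2 to compound 3 (0.21 log units; within the scatter). For compound 3 the estimated value is 5000 nM, with an expected range from 1500 nM to 20000 nM.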

Compound 3, concentration for 50% growth inhibition: 5130 nM
For compound 3 the middle estimate is 1.0-fold (0.01 log units) below the measured one, and the stated range covers the measured number.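

In this assay, going by these compounds alone, the swap of phenyl for chloro on an aromatic carbon, para to a large group, gives a 1.7-fold higher number from compound 2 to compound 3 (0.22 log units; within the scatter) and is the first measured step in this set. At this position, then, a six-membered aromatic ring of carbon only can give way to a single chlorine atom without a difference that stands out from repeated measurements. Nothing available explains this result, so no cause can be given for it.

A single step cannot show how other groups would read on the same aromatic carbon, such as an amine, a carboxylic acid or a nitrile. Also open, as far as these compounds go, is how a longer chain would compare with the chain shared by compound 2 and compound 3.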